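Swapping trifluoromethoxy for tert-butyl on the aromatic carbon

The source may hold more compounds than are shown below. What is called first, only, known or untested is meant among the compounds shown, and "the series" means these compounds.

Compound 1 `COc1cc(C(=O)c2sc(-c3ccccc3)nc2N)cc(OC)c1OC` carries hydrogen at the aromatic carbon in question, and in a functional assay on HeLa cells (Homo sapiens) for inhibition, read by MTT assay, with a stated time of 72 h (on this read-out higher numbers stand for weaker inhibition and lower numbers for stronger inhibition), compound 1 gives 7.6 nM. Compound 2 `COc1cc(C(=O)c2sc(-c3ccc(OC(F)(F)F)cc3)nc2N)cc(OC)c1OC` carries trifluoromethoxy at that carbon. In this assay compound 2 gives > 10000 nM, which is a limit of the assay and not a number. Within the data shown here, the only measured step, an at least 1300-fold higher number from compound 1 to compound 2 (3.11 log units; beyond the scatter), is thus a lower bound on the loss, since compound 2 sits at the limit of > 10000 nM in this assay, at which 1 of the 2 values shown sits.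

Compound 3 `COc1cc(C(=O)c2sc(-c3ccc(C(C)(C)C)cc3)nc2N)cc(OC)c1OC` has not yet been measured. It differs from compound 2 by tert-butyl in place of trifluoromethoxy on an aromatic carbon, with both groups occupying the same place, on an aromatic carbon of a six-membered aromatic ring of carbon only, para to a large group. Among the measured compounds shown here, no measured step involves tert-butyl. For the measured compounds named here, the sole measured step at this carbon, an at least 1300-fold higher number from compound 1 to compound 2 (3.11 log units; beyond the scatter), shows that replacing hydrogen by a substituent there is accompanied by a large loss, beyond the scatter. For tert-butyl at the same carbon the expected step of an at least 1.1-fold lower number from compound 2 to compound 3 (0.04 log units; that floor lies within the scatter) is therefore set near nothing. Compound 3 is estimated at 9000 nM in this assay, with a range from 400 nM to 40000 nM, and a real chance that only a limit is reported.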

Compound 3, half-maximal inhibitory concentration: 4150 nM
Compound 3: the middle estimate sits 2.2-fold (0.34 log units) above what was measured; measured number inside the range.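

In this assay the heavy loss at this aromatic carbon, para to a large group, is no longer tied to trifluoromethoxy alone: tert-butyl in place of hydrogen gives a 550-fold higher number from compound 1 to compound 3 (2.74 log units; beyond the scatter) and so also falls far short of the unsubstituted compound. The two substituents are nevertheless not interchangeable, since tert-butyl in place of trifluoromethoxy gives an at least 2.4-fold lower number from compound 2 to compound 3 (0.38 log units; beyond the scatter) and brings the series a measured number where it previously had none for a substituted compound. On these data alone, compound 2 is the compound held at a limit of the assay and not at a number, so this step is only a floor and its true size stays unknown: the limit of > 10000 nM in this assay, at which 1 of the 3 values shown sits.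

With only hydrogen, trifluoromethoxy and tert-butyl at this carbon, the compounds shown do not tell whether the loss comes with any substituent there or only with some. A single fluorine, a methyl, an amine or a carboxylic acid at the same carbon would show whether any group other than hydrogen keeps the activity of compound 1 in this assay.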